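Adding 4-acetylphenyl to compound 2

A few compounds are considered here, and "the series" means these few. Any claim that something is new, unique, unknown or untested is made for them only; others in the source may bear on it.

In a functional assay on HCT-116 cells (Homo sapiens) for antiproliferative activity, read by MTT assay, with a stated time of 72 h (on this read-out higher numbers stand for weaker inhibition and lower numbers for stronger inhibition), compound 2 `O=C(CCc1cccc2c1C(O)OC2)Nc1ccccc1` gives 22000 nM, and compound 1 `CC(=O)c1ccc(-c2cccc(NC(=O)CCc3ccc4c(c3)B(O)OC4)c2)cc1` gives 19000 nM. Among the measured compounds shown here, these are the only two measurements available, and they lie within the usual scatter of each other, so compound 2 stands level with compound 1.

The next compound to be tested is compound 3 `CC(=O)c1ccc(-c2cccc(NC(=O)CCc3cccc4c3C(O)OC4)c2)cc1`. Its structure differs from that of compound 2 by 4-acetylphenyl in place of hydrogen on an aromatic carbon, meta to a large group. For the measured compounds named here, no measured pair shows this change on its own, so its size cannot be read directly from the data. Going by the values given here, the only guide is compound 1, which also bears 4-acetylphenyl and gives 19000 nM, within the scatter of the value for compound 2. A shift beyond the scatter in this assay is therefore not expected, and neither direction is clearly favoured. The estimated step of a 1.2-fold lower number from compound 2 to compound 3 (0.09 log units; within the scatter) stays within the scatter. For compound 3 the expected value is 18000 nM, with an estimated range of 7000 nM to 45000 nM.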

Compound 3, half-maximal inhibitory concentration: 18000 nM
Beside the measured number, compound 3's estimate shows no gap at the digits printed; the range from low to high includes it.
By their numbers in this assay, from the lowest: compounds 3, 1 and 2 (each within the scatter of the next).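

In this assay, among the compounds shown here, the step of a 1.2-fold lower number from compound 2 to compound 3 (0.09 log units; within the scatter) gives the first direct reading of 4-acetylphenyl in place of hydrogen on an aromatic carbon, meta to a large group: the entering group, with its six-membered aromatic ring of carbon only and its 9 heavy atoms, moves the number by no more than the scatter at this position. The second reading, a 1.1-fold lower number from compound 1 to compound 3 (0.02 log units; within the scatter), concerns a different place, the group on a saturated chain carbon, two bonds along the chain from a carbonyl carbon, where a group containing boron gives way to one containing only carbon and oxygen, and this exchange also stays within the scatter while 4-acetylphenyl is present. No measurement available here bears on why these steps stay so small.

The compounds shown leave open whether an amine or a carboxylic acid in place of 4-acetylphenyl would give a number beyond the scatter of these three values. They also leave open whether a longer chain in place of the present saturated chain would shift the number in either direction.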